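Chain extension on the amino substituent of compound 1

The compounds below may be only part of what the source reports. "The series", "measured", "known", "first", "only" and "open" are said of these compounds alone.

Compound 1 `CNc1nnc(Cn2c(=O)oc3ccc(C)cc32)s1` sits at the bottom of the numbers gathered so far: in a functional assay on the whole organism for inhibition, with Mus musculus as the target, read by paw edema, with a stated time of 180 min, at a dose of 100 mg/kg by the oral route (on this read-out higher numbers stand for a stronger effect at the one dose given and lower numbers for a weaker effect), compound 1 gives 21.4%. Compound 2 `CCCn1c(Cn2c(=O)oc3ccc(C)cc32)n[nH]c1=S` gives 24.1% in this assay, a number that lies within the scatter of the value for compound 1, so the two are not separated. Compound 3 `CCNC(=S)NNC(=O)Cn1c(=O)oc2ccc(C)cc21` gives 36.3% in this assay, a number beyond the scatter above compound 1. Going by the values given here, no single-point step between any two of these three compounds is available; they share the core but differ in more than one place, so only their separate values can be set side by side.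

Compound 4 `CCCNc1nnc(Cn2c(=O)oc3ccc(C)cc32)s1` has not been measured in this assay. It differs from compound 1 as follows: ethyl in place of hydrogen on a saturated chain carbon bound to a nitrogen on an aromatic ring. The change is the entry of two carbon atoms on the chain, with no new ring, donor, acceptor or charge.

Among the compounds with values here, no comparable step is recorded, so nothing in the data says which way such a change moves the read-out. The step from compound 1 to compound 4 is estimated at a number 2.6 percentage points higher from compound 1 to compound 4 (within the scatter), a size that does not go beyond the scatter in either direction. Compound 4 is accordingly expected to give about 24% in this assay, with a range from 12% to 38%.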

Compound 4, a percentage reported as inhibition, in the whole organism at one dose (the size of the read-out at that dose, not a potency): 31.3%
Estimate against measurement, compound 4: 7.3 percentage points below; the range from low to high includes it.
By their numbers in this assay, from the lowest: compounds 1, 2, 4 and 3 (each within the scatter of the next, the first and the last beyond it).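

In this assay, going by these compounds alone, the change from methylamino to propylamino gives the only single-place step so far: a number 9.9 percentage points higher from compound 1 to compound 4 (within the scatter), so the two compounds are not separated. Within the data shown here, the position, a saturated chain carbon bound to a nitrogen on an aromatic ring, therefore carries ethyl in place of hydrogen without the read-out leaving the scatter, something the earlier compounds, which differ in more than one place, could not show. No measurement in hand bears on what lies behind this step.

On these data alone, a single step within the scatter sets no direction for chain length, so whether the read-out depends on the chain at this position remains open. As far as these compounds go, whether a longer chain such as hexyl, a branched chain such as isopropyl, a benzyl group, or a chain ending in an amine or a carboxylic acid would separate from the methylamino compound 1 in this assay also remains open.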